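From compound 3 to compound 4: one added chloro

This account rests on a few compounds, and the source may have more. Where it says the series, first, only, none or still open, it means among the compounds named here.

Measured so far:
- Compound 1 `[O-][n+]1onc2ccc(/C=C/[S+]([O-])c3ccccc3)cc21`: 30000 nM; > 400000 nM (2 entries)
- Compound 2 `[O-][n+]1onc2ccc(/C=C\[S+]([O-])c3ccccc3)cc21`: 14000 nM
- Compound 3 `O=C(/C=C/c1ccc2no[n+]([O-])c2c1)c1ccccc1`: 47000 nM

All of these values come from an ADME assay on J774 cells (Mus musculus) for cytotoxicity, read by MTT assay, with a stated time of 48 h; a higher number here means a weaker inhibitor, a lower number a stronger inhibitor. Compound 1 has two entries that disagree (the several entries of compound 1 in this assay, 30000 nM; > 400000 nM (2 entries)), and one of them is a limit of the assay and not a number. That leaves two compounds with a single number. Of these, compound 3 has the higher number, so it is the weaker inhibitor of the pair. Compound 2 stands lower, and the gap between them lies beyond the usual scatter.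

Compound 4 `O=C(/C=C/c1ccc2no[n+]([O-])c2c1)c1ccc(Cl)cc1` has not yet been measured. It differs from compound 3 in one place, with chloro in place of hydrogen on an aromatic carbon, para to a large group (chloro in place of hydrogen on an aromatic carbon). Phenyl thus becomes 4-chlorophenyl. Within the data shown here, none of the measured compounds carries this chloro, so no measured step can guide the estimate. The starting point is therefore compound 3 at 47000 nM, and no step beyond the scatter is expected in this assay, with a slight lean towards a lower number. The expected change is a 1.3-fold lower number from compound 3 to compound 4 (0.13 log units; within the scatter). For compound 4 the estimated value is 35000 nM, with an expected range from 12000 nM to 100000 nM.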

Compound 4, half-maximal inhibitory concentration: 28000 nM
Estimate against measurement, compound 4: 1.3-fold (0.10 log units) above; the measured number falls inside the stated range.
By their numbers in this assay, from the lowest: compounds 2, 4 and 3 (each within the scatter of the next, the first and the last beyond it).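

Turning phenyl into 4-chlorophenyl gives a 1.7-fold lower number from compound 3 to compound 4 (0.22 log units; within the scatter) in this assay, so the two compounds cannot be told apart in this measurement. Among these compounds, the earlier compounds offered no step of a single change to read, which makes this the first direct look at what one substitution does here: at this position, on an aromatic carbon para to a large group, a chloro in place of hydrogen leaves the cell result of compound 4 within the usual scatter of that of compound 3. Nothing known about these compounds explains why the number stays within the scatter.

This is one group at one position, so it says nothing yet about whether a methoxy, an amine or a carboxylic acid at the same place would give a step beyond the scatter. It also leaves open whether the same chloro would behave alike on the phenyl of compound 1 or compound 2, which carry a different link to the shared core.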